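The source may hold more compounds than are shown below. What is called first, only, known or untested is meant among the compounds shown, and "the series" means these compounds.

Compound 1 `CNc1nc(C)c2cc(-c3cnc(OC)c(NS(=O)(=O)c4ccc(F)cc4F)c3)cc(OC3CCOCC3)c2n1` gives 59 nM
Compound 2 `CNc1nc(C)c2cc(-c3cnc(OC)c(NS(=O)(=O)c4ccc(F)cc4F)c3)cc(OCC3CCOC3)c2n1` gives 310 nM

In a functional assay on NCI-H460 cells (Homo sapiens) for cytotoxicity, read by MTT assay, with a stated time of 96 h (on this read-out lower numbers stand for stronger inhibition and higher numbers for weaker inhibition), compound 2 stands higher of the two at 310 nM and is thus the weaker inhibitor of the pair. Compound 3 `CNc1nc(C)c2cc(-c3cnc(OC)c(NS(=O)(=O)c4ccc(F)cc4F)c3)cc(OCC3CCOCC3)c2n1` has not yet been measured. It differs from compound 2 only by oxan-4-yl in place of oxolan-3-yl on a saturated chain carbon bound to an oxygen on an aromatic ring and nothing else changes. For the measured compounds named here, one measured step bears on this, a 5.3-fold higher number from compound 1 to compound 2 (0.72 log units; beyond the scatter) with (oxolan-3-yl)methyl in place of oxan-4-yl on an oxygen on an aromatic ring. That step altered ring and chain together, and the data do not separate the two. Compound 3 carries the oxan-4-yl of compound 1 on the chain of compound 2, so only part of that step is expected to be recovered, toward lower numbers in this assay and smaller in size than the measured step. The expected change is a 2.2-fold lower number from compound 2 to compound 3 (0.35 log units; beyond the scatter) on this reasoning. Compound 3 is estimated at 140 nM with an expected range from 50 nM to 400 nM in this read-out.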

Compound 3, half-maximal inhibitory concentration: 400 nM
Compound 3: the middle estimate sits 2.9-fold (0.46 log units) below what was measured, and the stated range covers the measured number.
By their numbers in this assay, from the lowest: compound 1; then compounds 2 and 3 (each within the scatter of the next).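

In this assay, oxan-4-yl in place of oxolan-3-yl on a saturated chain carbon bound to an oxygen on an aromatic ring gives a step within the scatter (from a 1.3-fold higher number from compound 2 to compound 3 (0.11 log units; within the scatter)), so at this place the data do not tell the two rings apart. Placing the chain carbon under an unchanged oxan-4-yl, by contrast, gives a step beyond the scatter (a 6.8-fold higher number from compound 1 to compound 3 (0.83 log units; beyond the scatter)), so among these three compounds the higher number goes with the (oxan-4-yl)methyl or (oxolan-3-yl)methyl chain, not with ring size, and this separates what the earlier step had left joined. Nothing available explains why the chain carbon matters here.

All three compounds carry a saturated ring with one oxygen, which leaves open how a piperidin-4-yl, with a ring nitrogen in place of that oxygen, or a plain cyclohexyl would read on the oxygen on the aromatic ring. Also open, from the compounds shown here alone, are whether a longer chain ahead of the oxan-4-yl would raise the number further and whether oxolan-3-yl set directly on that oxygen would match oxan-4-yl.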